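The compounds below may be only part of what the source reports. "The series", "measured", "known", "first", "only" and "open" are said of these compounds alone.

Measured in a functional assay on 518A2 cells (Homo sapiens) for cytotoxicity, read by MTT assay, with a stated time of 72 h; on this read-out higher numbers stand for weaker inhibition and lower numbers for stronger inhibition:
- Compound 1 `CN1C/C(=C\c2ccccc2F)C(=O)/C(=C/c2ccccc2F)C1`: 1800 nM
- Compound 2 `CN1C/C(=C\c2c(F)cc(F)cc2F)C(=O)/C(=C/c2c(F)cc(F)cc2F)C1`: > 10000 nM, a limit of the assay and not a number

In this assay, among the compounds with values here, compound 1 holds the only numerical value, 1800 nM. The result for compound 2 is a limit, > 10000 nM. Within the data shown here, the two compounds therefore offer no measured step, and neither of them bears on a change at the amine end of the core.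

Compound 3 `CCN1C/C(=C\c2ccccc2F)C(=O)/C(=C/c2ccccc2F)C1` keeps the core and both aryl groups of compound 1. It differs by methyl in place of hydrogen on a saturated chain carbon bound to an amine nitrogen in a ring, which is methyl in place of hydrogen on a saturated chain carbon bound to an amine nitrogen in a ring, or, cut one bond further out, methyl to ethyl.

Among the measured compounds shown here, with no measured step to size this change, no shift beyond the scatter is expected in this assay, and neither direction is favoured. The expectation is anchored on compound 1 at 1800 nM. The estimate for compound 3 is 1500 nM, with an expected range from 500 nM to 5000 nM. This estimate amounts to a 1.2-fold lower number from compound 1 to compound 3 (0.08 log units; within the scatter).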

Compound 3, half-maximal inhibitory concentration: 1800 nM
Compound 3: the middle estimate sits 1.2-fold (0.08 log units) below what was measured; measured number inside the range.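

In this assay, the change from methyl to ethyl gives no change at the digits printed from compound 1 to compound 3 (within the scatter). This is the only measured step among the compounds shown, since compound 1 and compound 2 offered none, and it shows that methyl in place of hydrogen on a saturated chain carbon bound to an amine nitrogen in a ring, with the shared core and both aryl groups kept, leaves the cytotoxic read-out within the scatter. Nothing at hand bears on why this change leaves the result where it is.

Whether the position would take larger or different groups stays open, as a longer chain such as propyl, a benzyl group, a hydrogen on the ring nitrogen, or a carboxylic acid at the end of the chain are not among the compounds shown. A single step also cannot tell how the same change would read with the aryl groups of compound 2, whose > 10000 nM in this assay is a limit of the assay and not a number.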